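This account rests on a few compounds, and the source may have more. Where it says the series, first, only, none or still open, it means among the compounds named here.

Compound 3 `CC(C)C[C@H](NC(=O)CN(c1ncnc2c1ncn2C1CCCCO1)C1CC1)C(=O)OCc1ccccc1` gives 28.2% in a functional assay on the whole organism (Tail, strain ICR) with Mus musculus as the target, in the tail flick test, with a stated time of 90 min, at a dose of 25 umol/kg by the oral route; on this read-out higher numbers stand for a stronger effect at the one dose given and lower numbers for a weaker effect. Among the three measured numbers it is the second highest, although all three lie within the scatter of one another: compound 1 `O=C(CN(c1ncnc2c1ncn2C1CCCCO1)C1CC1)N[C@@H](CCC(=O)OCc1ccccc1)C(=O)OCc1ccccc1` gives 25.2% in this assay, and compound 2 `CC(C)(C)OC(=O)NCCCC[C@H](NC(=O)CN(c1ncnc2c1ncn2C1CCCCO1)C1CC1)C(=O)OCc1ccccc1` gives 32.9% in this assay. The measured steps are a number 3 percentage points higher from compound 1 to compound 3 (within the scatter), a number 4.7 percentage points lower from compound 2 to compound 3 (within the scatter) and a number 7.7 percentage points higher from compound 1 to compound 2 (within the scatter), each within the scatter. Compound 4 `C[C@@H](O)[C@H](NC(=O)CN(c1ncnc2c1ncn2C1CCCCO1)C1CC1)C(=O)OCc1ccccc1` differs from compound 3 by 1-hydroxyethyl in place of isobutyl on a saturated chain carbon bound to an amide-type nitrogen and a carbonyl carbon. For the measured compounds named here, no measured step exchanges isobutyl for 1-hydroxyethyl at this place, but every side-chain exchange measured so far has stayed within the scatter, so compound 4 is expected to show a number 0.2 percentage points lower from compound 3 to compound 4 (within the scatter) in this assay. Compound 4 is estimated at 28%, with a range from 14% to 42%.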

Compound 4, a percentage reported as activity, at one dose (the size of the read-out at that dose, not a potency): 23.4%
The estimate for compound 4 lay 4.6 percentage points above the measured number; the range from low to high includes it.
By their numbers in this assay, from the lowest: compounds 4, 1, 3 and 2 (each within the scatter of the next).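

In this assay, 1-hydroxyethyl at this saturated chain carbon bound to an amide-type nitrogen and a carbonyl carbon gives no step beyond the scatter: (a number 4.8 percentage points lower from compound 3 to compound 4 (within the scatter)), (a number 9.5 percentage points lower from compound 2 to compound 4 (within the scatter)) and (a number 1.8 percentage points lower from compound 1 to compound 4 (within the scatter)). An oxygen-bearing side chain with a defined stereocentre therefore still leaves all four compounds within the scatter of one another. Nothing available accounts for these small differences. From the compounds shown here alone, whether a free amine or a carboxylic acid on this side chain would produce a step beyond the scatter remains open.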